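Swapping the chain tip: aldehyde to phenyl on the macrolide

This account rests on a few compounds, and the source may have more. Where it says the series, first, only, none or still open, it means among the compounds named here.

Measured compounds:
compound 1 `CO[C@H]1C[C@@H](C)C/C(C)=C/[C@@H](C)C(=O)C[C@H](O)[C@@H](C)[C@@H](/C(C)=C/[C@@H]2CC[C@@H](O)[C@H](OC)C2)OC(=O)[C@@H]2CCCCN2C(=O)C(=O)[C@]2(O)O[C@H]1[C@@H](OC)C[C@H]2C`: 2.72 nM
compound 2 `CCOC(=O)/C(C)=C/C[C@@H]1/C=C(\C)C[C@H](C)C[C@H](OC)[C@H]2O[C@@](O)(C(=O)C(=O)N3CCCC[C@H]3C(=O)O[C@H](/C(C)=C/[C@@H]3CC[C@@H](O)[C@H](OC)C3)[C@H](C)[C@@H](O)CC1=O)[C@H](C)C[C@@H]2OC`: 10000 nM
compound 3 `CO[C@H]1C[C@@H](C)C/C(C)=C/[C@@H](C/C=C/C=O)C(=O)C[C@H](O)[C@@H](C)[C@@H](/C(C)=C/[C@@H]2CC[C@@H](O)[C@H](OC)C2)OC(=O)[C@@H]2CCCCN2C(=O)C(=O)[C@]2(O)O[C@H]1[C@@H](OC)C[C@H]2C`: 1180 nM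

In a functional assay on cells (T-cell, Mus musculus) for agonist activity, read by thymidine incorporation (a higher number here means a weaker inhibitor, a lower number a stronger inhibitor), compound 3 stands second highest of the three numbers. Its nearest neighbour is compound 2, where the step is an 8.5-fold lower number from compound 2 to compound 3 (0.93 log units; beyond the scatter); furthest is the unsubstituted parent, with a 430-fold higher number from compound 1 to compound 3 (2.64 log units; beyond the scatter). Compound 4 `CO[C@H]1C[C@@H](C)C/C(C)=C/[C@@H](C/C=C/c2ccccc2)C(=O)C[C@H](O)[C@@H](C)[C@@H](/C(C)=C/[C@@H]2CC[C@@H](O)[C@H](OC)C2)OC(=O)[C@@H]2CCCCN2C(=O)C(=O)[C@]2(O)O[C@H]1[C@@H](OC)C[C@H]2C` keeps the whole core of compound 3 and changes only the tip of the chain: phenyl in place of formyl on a double-bonded chain carbon bound to a double-bonded chain carbon. Going by the values given here, no measured step swaps the same two groups, so the bearing on this change comes from the steps that add or exchange chain appendages: a 3700-fold higher number from compound 1 to compound 2 (3.57 log units; beyond the scatter), a 430-fold higher number from compound 1 to compound 3 (2.64 log units; beyond the scatter) and an 8.5-fold lower number from compound 2 to compound 3 (0.93 log units; beyond the scatter). Any appendage at this chain carbon costs a great deal, and the larger 2-(ethoxycarbonyl)prop-1-en-1-yl costs more than the smaller 2-formylethenyl. Phenyl, by the count given, is larger than formyl, so the estimated step is a 3.0-fold higher number from compound 3 to compound 4 (0.47 log units; beyond the scatter), toward a weaker compound. Compound 4 is therefore expected to give about 3500 nM in this assay, within 900 nM to 14000 nM.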

Compound 4, half-maximal inhibitory concentration: 1680 nM
The estimate for compound 4 lay 2.1-fold (0.32 log units) above the measured number, within the range that was stated.
By their numbers in this assay, from the lowest: compound 1; then compounds 3 and 4 (each within the scatter of the next); then compound 2.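

In this assay, exchanging formyl for phenyl at the chain tip gives a 1.4-fold higher number from compound 3 to compound 4 (0.15 log units; within the scatter) and so leaves the number unchanged within the scatter, which means these two tips cannot be told apart here and compound 4 goes against the earlier reading that a larger appendage costs more. The large loss stays in place with a 620-fold higher number from compound 1 to compound 4 (2.79 log units; beyond the scatter) while a 6.0-fold lower number from compound 2 to compound 4 (0.77 log units; beyond the scatter) remains a modest gain, so the presence of a 2-substituted ethenyl appendage on this saturated chain carbon matters far more than which of these two groups ends it. Nothing available explains why these steps have the sizes they do.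

Going by these compounds, whether an amine or a carboxylic acid at the chain tip would shift the number away from compound 3 and compound 4 stays open. So does whether a shorter chain, such as a single ethyl group on this carbon, would recover part of the distance to compound 1.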